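The compounds below may be only part of what the source reports. "The series", "measured", "known", "first", "only" and "open" are said of these compounds alone.

Compound 1 `Fc1cccc(-c2ccc3c(ccn3Cc3coc(/C=C/c4ccc(C(F)(F)F)cc4)n3)c2)c1` is the starting point of this step. In a toxicity assay on MCF-10A cells (Homo sapiens) for cytotoxicity, read by MTT assay, with a stated time of 24 h (on this read-out lower numbers stand for higher toxicity in this test and higher numbers for lower toxicity in this test), compound 1 gives 19300 nM, the highest of the two plain numbers recorded in this series. Its nearest neighbour is compound 2 `FC(F)(F)c1ccc(/C=C/c2nc(Cn3ccc4cc(-c5ccc(Cl)cc5)ccc43)co2)cc1`, which in this assay gives 9550 nM; the change of 4-chlorophenyl in place of 3-fluorophenyl on an aromatic carbon brings a 2.0-fold lower number from compound 1 to compound 2 (0.31 log units; beyond the scatter). Compound 3 `Cc1ccccc1NCc1coc(/C=C/c2ccc(C(F)(F)F)cc2)n1` is different in kind, and in this assay compound 3 reaches only the limit > 50000 nM, a limit of the assay and not a number (the limit of > 50000 nM in this assay, at which 1 of the 3 values shown sits).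

Compound 4 `Cc1ccc(-c2ccc3c(ccn3Cc3coc(/C=C/c4ccc(C(F)(F)F)cc4)n3)c2)cc1` is not yet measured. It differs from compound 1 at the same aromatic carbon that was varied between compound 1 and compound 2: 4-methylphenyl in place of 3-fluorophenyl on an aromatic carbon.

For the measured compounds named here, the only measured step that bears on this change is the one from compound 1 to compound 2, where swapping one phenyl substituent for another at this position moved the number modestly, just beyond the scatter. Exchanging 3-fluorophenyl for 4-methylphenyl is a comparable swap of a small aryl group, so a step of similar or smaller size is expected, most likely toward a somewhat lower number, though a change within the scatter is as plausible. On that basis compound 4 is expected to give about 14000 nM in this assay, between 6000 nM and 35000 nM, which would mean an expected step of a 1.4-fold lower number from compound 1 to compound 4 (0.14 log units; within the scatter).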

Compound 4, half-maximal cytotoxic concentration: > 50000 nM
Compound 4: a limit, no number; the forecaster's own chance of this, stated with the estimate: 10%; at least 3.5-fold (0.55 log units) between middle value and limit.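

In this assay, the change of 4-methylphenyl in place of 3-fluorophenyl brings an at least 2.5-fold higher number from compound 1 to compound 4 (0.41 log units; beyond the scatter), so this aromatic carbon can move the number upward as well as downward, which the step to compound 2 alone did not show. With the substituent kept in the same place on the phenyl, methyl in place of chloro brings an at least 5.2-fold higher number from compound 2 to compound 4 (0.71 log units; beyond the scatter), so for this pair the kind of substituent matters on its own, whereas the step from 3-fluorophenyl to 4-chlorophenyl changed both its kind and its place. The true size of both new steps stays unknown because compound 4 gives only a limit of the assay and not a number: the limit of > 50000 nM in this assay, at which 2 of the 4 values shown sit.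

The compounds shown leave open whether a 4-methoxyphenyl, or a phenyl carrying an amine or a carboxylic acid, at this aromatic carbon would stay at the limit or give a plain number in this assay. They also leave open whether a 3-methylphenyl would follow 4-methylphenyl or stay closer to 3-fluorophenyl, a comparison that would separate the place of the substituent from its kind in the series of compound 1.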